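A few compounds are considered here, and "the series" means these few. Any claim that something is new, unique, unknown or untested is made for them only; others in the source may bear on it.

Measured compounds:
- compound 1 `N=C(Nc1cccc(C(F)(F)F)c1)c1cc2c(-c3ccccc3)n[nH]c2cn1`: 22300 nM in a functional assay on MDA-MB-231 cells (Homo sapiens) for cytotoxicity, read by MTT assay, with a stated time of 72 h; on this read-out lower numbers stand for stronger inhibition and higher numbers for weaker inhibition
- compound 2 `Cn1nc(-c2ccccc2)c2cc(C(=N)Nc3cccc(C(F)(F)F)c3)ncc21`: 21400 nM
- compound 3 `N=C(Nc1cccc(C(F)(F)F)c1)c1cc2cn[nH]c2cn1`: > 50000 nM, which is a limit of the assay and not a number

Compound 3 stands at the edge of what this assay reports. In this assay compound 3 gives > 50000 nM, a limit rather than a measured number, as described by the limit of > 50000 nM in this assay, at which 1 of the 3 values shown sits. Compound 3 is reached from compound 1 by an at least 2.2-fold higher number from compound 1 to compound 3 (0.35 log units; beyond the scatter).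

Compound 4 `Cn1ncc2cc(C(=N)Nc3cccc(C(F)(F)F)c3)ncc21` differs from compound 3 in a single place: methyl in place of hydrogen on an aromatic nitrogen. The same exchange has been measured once already, between compound 1 and compound 2, where it gave a 1.0-fold lower number from compound 1 to compound 2 (0.02 log units; within the scatter). That step offers no sign of a shift in either direction, so no step beyond the scatter is expected in this assay here either. Compound 4 is therefore expected to come out at about 60000 nM, with a range from 30000 nM to 150000 nM, and most probably again as a limit. The estimated step is a step that the limit leaves unreadable from compound 3 to compound 4.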

Compound 4, half-maximal inhibitory concentration: > 50000 nM
Compound 4 gave a limit, no number (the forecaster's own chance of this, stated with the estimate: 80%); the middle value is on the limit's open side.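

Replacing phenyl with hydrogen on the aromatic carbon now also gives a change on the core that carries methyl on the aromatic nitrogen, with an at least 2.3-fold higher number from compound 2 to compound 4 (0.36 log units; beyond the scatter) in this assay. The same exchange can therefore be followed on two cores, one with hydrogen and one with methyl on that nitrogen, and it points the same way on both: the same change on two cores in this assay, an at least 2.2-fold higher number (0.35 log units; beyond the scatter) from compound 1 to compound 3 and an at least 2.3-fold higher number (0.36 log units; beyond the scatter) from compound 2 to compound 4; the limit leaves it open whether they differ. The methyl step itself cannot be read, since compound 3 and compound 4 both stand at a limit of the assay and give no number: the limit of > 50000 nM in this assay, at which 2 of the 4 values shown sit.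

From the compounds shown here alone, what remains open is how far past that limit compound 3 and compound 4 lie, and so whether methyl changes anything once phenyl is gone. Also open, going by these compounds, is how another group on that aromatic carbon, such as an amine, a carboxylic acid or a longer chain, would compare with phenyl.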